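This account rests on a few compounds, and the source may have more. Where it says the series, first, only, none or still open, it means among the compounds named here.

Compound 1 `CCN1C(=O)CSC1c1cccc(C(=O)NCCCCc2ccccc2)c1`: > 1000 nM
Compound 2 `O=C(NCCCCc1ccccc1)c1cccc(C2SCC(=O)N2c2ccc(-c3ccccc3)cc2)c1`: > 1000 nM

In a functional assay on HOS-TE85 cells (Homo sapiens) for inhibition, read by CCK-8 assay, with a stated time of 72 h (a lower number here means a stronger inhibitor, a higher number a weaker inhibitor), compound 2 gives > 1000 nM, which is a limit of the assay and not a number. Compound 1 gives > 1000 nM, which is also a limit. So compound 2 has no exact potency to start from.

Compound 3 `O=C(NCCCCc1ccccc1)c1cccc(C2SCC(=O)N2c2ccccn2)c1` keeps the rest of compound 2 and changes one group, with pyridin-2-yl in place of 4-phenylphenyl on an amide-type nitrogen in a ring.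

Among the measured compounds shown here, only one measured step bears on this position: a step that the two limits leave unreadable from compound 1 to compound 2. Neither ethyl in compound 1 nor 4-phenylphenyl in compound 2 gave a number, as the limit of > 1000 nM in this assay, at which 2 of the 2 values shown sit, shows. That step therefore offers no size or direction to carry over. No clear step in either direction is expected in this assay, and the likeliest outcome is another limit rather than a number.

The expected change is a step that the limit leaves unreadable from compound 2 to compound 3. For compound 3, the estimated value is 2500 nM, with an expected range from 800 nM to 10000 nM.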

Compound 3, half-maximal inhibitory concentration: 19.7 nM
Compound 3: the middle estimate sits 130-fold (2.10 log units) above what was measured, outside the stated range (below it).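

In this assay, the group on the amide-type nitrogen in the ring can decide whether a compound gives a measurable potency at all. Pyridin-2-yl in place of 4-phenylphenyl gives an at least 50-fold lower number from compound 2 to compound 3 (1.70 log units; beyond the scatter), and the same group in place of ethyl gives an at least 50-fold lower number from compound 1 to compound 3 (1.70 log units; beyond the scatter), so it stands apart from both a much smaller and a much larger group at this position. The earlier step between compound 1 and compound 2 could not be read and gave no hint of this, as neither compound has an exact number, only a limit: the limit of > 1000 nM in this assay, at which 2 of the 3 values shown sit.

From the compounds shown here alone, what remains open is which feature of pyridin-2-yl matters, since the change from 4-phenylphenyl both lowers the number of heavy atoms and brings in a ring nitrogen with a hydrogen-bond acceptor. A plain phenyl on this nitrogen would separate those two changes, and pyridin-3-yl or pyridin-4-yl would show whether the place of the ring nitrogen counts.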